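Sulfonyl versus carbonyl cap on the amine nitrogen

The source may hold more compounds than are shown below. What is called first, only, known or untested is meant among the compounds shown, and "the series" means these compounds.

Compound 3 `O=C(NCCNc1nccc(-c2c(-c3cccc(F)c3)nc3sccn23)n1)c1ccc(C(F)(F)F)cc1` gives, in a functional assay on A-375 cells (Homo sapiens) for cytotoxicity, read by MTT assay (on this read-out higher numbers stand for weaker inhibition and lower numbers for stronger inhibition), 8710 nM. Its nearest neighbour on the numbers is compound 1 `O=S(=O)(NCCNc1nccc(-c2c(-c3cccc(F)c3)nc3sccn23)n1)c1ccc(F)cc1`, which in this assay gives 9450 nM; the step of a 1.1-fold lower number from compound 1 to compound 3 (0.04 log units; within the scatter). Compound 2 `O=S(=O)(NCCCNc1nccc(-c2c(-c3cccc(F)c3)nc3sccn23)n1)c1ccc(Cl)cc1` gives 5900 nM, and the step of a 1.6-fold lower number from compound 1 to compound 2 (0.20 log units; within the scatter). All three numbers thus sit together within the usual scatter, and compound 3 stands among them without a separation that can be read as real.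

Compound 4 `O=S(=O)(NCCNc1nccc(-c2c(-c3cccc(F)c3)nc3sccn23)n1)c1cccc(F)c1` carries (3-fluorophenyl)sulfonyl in place of (4-(trifluoromethyl)phenyl)carbonyl on an amine nitrogen. The step bearing most directly on this is a 1.1-fold lower number from compound 1 to compound 3 (0.04 log units; within the scatter), which swaps a (4-fluorophenyl)sulfonyl for the (4-(trifluoromethyl)phenyl)carbonyl on the same amine nitrogen and stays within the scatter; the step of a 1.6-fold lower number from compound 1 to compound 2 (0.20 log units; within the scatter), also within the scatter, shows that changes around the sulfonyl aryl cap have not moved the numbers either. The expectation for compound 4 in this assay is therefore no step beyond the scatter, a 1.0-fold higher number from compound 3 to compound 4 (0.01 log units; within the scatter). Compound 4 is estimated at 9000 nM, with a range of 4000 nM to 20000 nM.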

Compound 4, half-maximal inhibitory concentration: 14900 nM
The estimate for compound 4 lay 1.7-fold (0.22 log units) below the measured number; the range from low to high includes it.
By their numbers in this assay, from the lowest: compounds 2, 3, 1 and 4 (each within the scatter of the next, the first and the last beyond it).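

On the sulfonyl sulfur, 3-fluorophenyl in place of 4-fluorophenyl gives a 1.6-fold higher number from compound 1 to compound 4 (0.20 log units; within the scatter), and on the amine nitrogen, (3-fluorophenyl)sulfonyl in place of (4-(trifluoromethyl)phenyl)carbonyl gives a 1.7-fold higher number from compound 3 to compound 4 (0.23 log units; within the scatter), so neither exchange separates the compounds in this assay. The first separation in the set is a 2.5-fold higher number from compound 2 to compound 4 (0.40 log units; beyond the scatter), a modest step in which ((3-fluorophenyl)sulfonyl)amino replaces (((4-chlorophenyl)sulfonyl)amino)methyl on a saturated chain carbon, with the chain and the aryl group changing together. No supporting data bear on any of these steps.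

The compounds shown do not tell whether that separation belongs to the chain or to the aryl group. Also open, from the compounds shown here alone, is how the series responds to a cap outside the aryl sulfonyl and aroyl groups, such as a methylsulfonyl, or to a chain longer than that of compound 2.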